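Amino acid tail changes on a shared core

The compounds below may be only part of what the source reports. "The series", "measured", "known", "first", "only" and "open" are said of these compounds alone.

Compound 1 `CC[C@H](C)[C@H](NCC(=O)NNC(=O)COc1ccc(-c2nc3ccccc3s2)cc1OC)C(=O)O` gives 3540 nM in a functional assay on HepG2 cells (Homo sapiens) for inhibition, read by MTT assay, with a stated time of 3 days (on this read-out higher numbers stand for weaker inhibition and lower numbers for stronger inhibition), the second highest of the three numbers and within the scatter of both neighbours. Compound 2 `COc1cc(-c2nc3ccccc3s2)ccc1OCC(=O)NNC(=O)CN[C@@H](CS(=O)(=O)O)C(=O)O` gives 3690 nM and compound 3 `CCOC(=O)[C@@H](NCC(=O)NNC(=O)COc1ccc(-c2nc3ccccc3s2)cc1OC)[C@@H](C)CC` gives 3460 nM. Compound 4 `CCOC(=O)[C@H](CS)NCC(=O)NNC(=O)COc1ccc(-c2nc3ccccc3s2)cc1OC` is unmeasured. Its difference from compound 1 is 1-(ethoxycarbonyl)-2-sulfanylethyl in place of 1-carboxy-2-methylbutyl on an amine nitrogen. Among the measured compounds shown here, two measured steps bear on it: the ester for acid swap, a 1.0-fold lower number from compound 1 to compound 3 (0.01 log units; within the scatter), and the side-chain swap on the same chain carbon, a 1.0-fold higher number from compound 1 to compound 2 (0.02 log units; within the scatter); the combined swap a 1.1-fold lower number from compound 2 to compound 3 (0.03 log units; within the scatter) is likewise flat. No step beyond the scatter is therefore expected, so compound 4 is estimated at 3500 nM (range 1800 nM to 7000 nM), a step of a 1.0-fold lower number from compound 1 to compound 4 (0.00 log units; within the scatter).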

Compound 4, half-maximal inhibitory concentration: 3760 nM
Beside the measured number, compound 4's estimate is 1.1-fold (0.03 log units) below it; low and high end bracket the measured number.
By their numbers in this assay, from the lowest: compounds 3, 1, 2 and 4 (each within the scatter of the next).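

Sulfanylmethyl on the saturated chain carbon, carried with the ethyl ester, adds a third side chain to sec-butyl and sulfomethyl, and in this assay no step leaves the scatter (a 1.1-fold higher number from compound 1 to compound 4 (0.03 log units; within the scatter); a 1.1-fold higher number from compound 3 to compound 4 (0.04 log units; within the scatter); a 1.0-fold higher number from compound 2 to compound 4 (0.01 log units; within the scatter)). Among the compounds shown here, the change of side chain and ester together on the amine nitrogen is as flat as either change alone in the earlier compounds. No evidence on this result is available.

On these data alone, whether an amine or a longer chain on this carbon would move the number remains open. So does the effect of a basic amine in place of the ester on the sulfanylmethyl side chain.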